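This account rests on a few compounds, and the source may have more. Where it says the series, first, only, none or still open, it means among the compounds named here.

Compound 1 `C=C(CC)C(=O)c1ccc(OCC(=O)Nc2ccc(C(=O)O)cn2)c(Cl)c1Cl` stands at the highest number of the three measured compounds in a functional assay on CLL cells (Homo sapiens) for cytotoxicity, read by MTT assay, with a stated time of 48 h; a higher number here means that more compound is needed for the effect, a lower number that less compound is needed: compound 1 gives 14900 nM. Compound 2 `C=C(CC)C(=O)c1ccc(OCC(=O)Nc2ccc3cc(C(=O)O)ccc3c2)c(Cl)c1Cl` gives 3700 nM, and compound 3 `C=C(CC)C(=O)c1ccc(OCC(=O)Nc2ccc(/C=C/C(=O)NO)cc2)c(Cl)c1Cl` gives 2600 nM; each of these two lies beyond the scatter from compound 1. Compound 4 `C=C(CC)C(=O)c1ccc(OCC(=O)Nc2ccc(C(C)=O)cc2)c(Cl)c1Cl` has not yet been measured. Against compound 1 it carries 4-acetylphenyl in place of 5-carboxypyridin-2-yl on an amide-type nitrogen. Since the two other measured compounds, which likewise change the group on the amide nitrogen, both give lower numbers than compound 1, the expected step is a 3.0-fold lower number from compound 1 to compound 4 (0.47 log units; beyond the scatter), downward and beyond the scatter. Compound 4 is therefore estimated at 5000 nM in this assay, with a range from 1500 nM to 15000 nM.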

Compound 4, half-maximal effective concentration: 3900 nM
Compound 4: middle estimate off by 1.3-fold (0.11 log units), on the high side; the range from low to high includes it.
By their numbers in this assay, from the lowest: compounds 3, 2 and 4 (each within the scatter of the next); then compound 1.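

In this assay the step of a 3.8-fold lower number from compound 1 to compound 4 (0.58 log units; beyond the scatter) shows that 4-acetylphenyl, with no hydrogen-bond donor, can replace 5-carboxypyridin-2-yl on the amide-type nitrogen and still lower the number beyond the scatter. The step of a 1.5-fold higher number from compound 3 to compound 4 (0.18 log units; within the scatter) shows that acetyl and 2-(hydroxycarbamoyl)ethenyl on the aromatic carbon cannot be told apart here. Nothing available explains why these numbers differ.

As far as these compounds go, the ring nitrogen and the carboxylic acid leave together, so which of them matters stays open. A 4-carboxyphenyl group on the same nitrogen would separate the two.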